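Removing the Sulfur Substituent of Compound 3 Entirely

This account rests on a few compounds, and the source may have more. Where it says the series, first, only, none or still open, it means among the compounds named here.

The series shares one core and differs only in the group carried on the sulfur. Compound 1 `CC(C)c1n[nH]c2c(NCc3ccc(-c4ccccn4)cc3)nc(SCC3CNC(=O)O3)nc12` gives 80 nM in a functional assay on HT cells (Homo sapiens) for antiproliferative activity, read by fluorescence, with a stated time of 72 h (on this read-out lower numbers stand for stronger inhibition of growth and higher numbers for weaker inhibition of growth), compound 2 `CC(C)c1n[nH]c2c(NCc3ccc(-c4ccccn4)cc3)nc(SCCCN(C)C)nc12` gives 105 nM, and compound 3 `CC(C)c1n[nH]c2c(NCc3ccc(-c4ccccn4)cc3)nc(SC3CCCC3O)nc12` gives 567 nM. Compound 3 therefore stands with the highest number of the three: the steps of a 7.1-fold higher number from compound 1 to compound 3 (0.85 log units; beyond the scatter) and a 5.4-fold higher number from compound 2 to compound 3 (0.73 log units; beyond the scatter) both lie beyond the scatter, whereas a 1.3-fold higher number from compound 1 to compound 2 (0.12 log units; within the scatter) does not.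

Compound 4 `CC(C)c1n[nH]c2c(NCc3ccc(-c4ccccn4)cc3)nc(S)nc12` is obtained from compound 3 by the change (hydrogen in place of 2-hydroxycyclopentyl on a sulfur). Among the compounds with values here, no measured step removes a sulfur substituent altogether; the three steps available only exchange one substituent for another, and they show that such exchanges move the number by modest amounts, as in a 5.4-fold higher number from compound 2 to compound 3 (0.73 log units; beyond the scatter) and a 7.1-fold higher number from compound 1 to compound 3 (0.85 log units; beyond the scatter). Within the data shown here, the bare sulfanyl group has no counterpart among the measured compounds, so the expectation rests on that limited range of movement rather than on a direct precedent.

On this basis compound 4 is expected to give a higher number again, with the step of a 2.6-fold higher number from compound 3 to compound 4 (0.42 log units; beyond the scatter) judged beyond the scatter but uncertain in size. The estimate for compound 4 in this assay is 1500 nM, within a range from 300 nM to 8000 nM.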

Compound 4, concentration for 50% growth inhibition: 2760 nM
Beside the measured number, compound 4's estimate is 1.8-fold (0.26 log units) below it; measured number inside the range.
By their numbers in this assay, from the lowest: compounds 1 and 2 (each within the scatter of the next); then compound 3; then compound 4.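

Within the data shown here, compound 4 is the only compound here that carries hydrogen on the sulfur, so it gives the first view of the shared core without a carbon substituent at this place, and in this assay it has the weakest inhibition of growth of the four. Loss of the 2-hydroxycyclopentyl group still raises the number (a 4.9-fold higher number from compound 3 to compound 4 (0.69 log units; beyond the scatter)), even though that group already gave the highest number among the substituted compounds, and the same exchange reads as large from the other two compounds (a 26-fold higher number from compound 2 to compound 4 (1.42 log units; beyond the scatter); a 35-fold higher number from compound 1 to compound 4 (1.54 log units; beyond the scatter)). All three substituents shown on this sulfur, whether ring-bearing or an open chain with a dimethylamino end, therefore give lower numbers than hydrogen, with no compound against this, although the data offer no explanation for the difference.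

The compounds shown leave open whether a small group such as methyl on the sulfur would already recover most of the lost growth inhibition, or whether a longer chain or one ending in a carboxylic acid is needed. They also leave open whether the sulfur itself matters, as an oxygen or an amine nitrogen in its place would test.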